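The compounds below may be only part of what the source reports. "The series", "measured", "known", "first", "only" and "open" are said of these compounds alone.

Working notes on the series. Compound 1 `CCOc1ccc(-n2nncc2CN2C(=O)C3(C(C#N)=C(N)Oc4c3c3nc5ccccc5nc3c3ccccc43)c3ccccc32)cc1` carries the ethoxy group on the phenyl that sits on the triazole nitrogen, and in a functional assay on A549 cells (Homo sapiens) for antiproliferative activity, read by MTT assay, with a stated time of 48 h (on this read-out lower numbers stand for stronger inhibition and higher numbers for weaker inhibition), compound 1 gives 25200 nM. Compound 2 `N#CC1=C(N)Oc2c(c3nc4ccccc4nc3c3ccccc23)C12C(=O)N(Cc1cnnn1-c1ccc(N)cc1)c1ccccc12` has amino in place of ethoxy on that aromatic carbon. In this assay compound 2 reaches only the assay limit, > 50000 nM, so no number is known for it. The step of an at least 1.9-fold higher number from compound 1 to compound 2 (0.29 log units; that floor lies within the scatter) is thus bounded by that limit of > 50000 nM in this assay, at which 1 of the 2 values shown sits, and its true size is open. Compound 3 `N#CC1=C(N)Oc2c(c3nc4ccccc4nc3c3ccccc23)C12C(=O)N(Cc1cnnn1-c1ccc(Cl)c(Cl)c1)c1ccccc12` is the next member: 3,4-dichlorophenyl in place of 4-aminophenyl on an aromatic nitrogen. Among the measured compounds shown here, no measured step covers this exchange; the one step in hand concerns the same ring but a different substituent, so it gives only a rough anchor. Compound 3 is estimated at 30000 nM, with a range of 10000 nM to 60000 nM. That estimate corresponds to an expected step of an at least 1.6-fold lower number from compound 2 to compound 3 (0.22 log units; that floor lies within the scatter), with a fair chance that compound 3 again reports only the limit.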

Compound 3, half-maximal inhibitory concentration: > 50000 nM
Compound 3 gave a limit, no number; the forecaster's own chance of this, stated with the estimate: 40%; at least 1.6-fold (0.22 log units) between middle value and limit.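

Replacing 4-ethoxyphenyl with 3,4-dichlorophenyl on this aromatic nitrogen gives an at least 1.9-fold higher number from compound 1 to compound 3 (0.29 log units; that floor lies within the scatter), so this floor sets no order between the two groups. The step between compound 2 and compound 3 cannot be read, as both values are limits. With 4-aminophenyl and 3,4-dichlorophenyl, two groups that differ in their atoms and in their hydrogen-bond donor count both end at the limit in this assay, and only compound 1 keeps a number: the limit of > 50000 nM in this assay, at which 2 of the 3 values shown sit.

Going by these compounds, how far compound 2 and compound 3 truly lie from compound 1 remains open. Also open, on these data alone, is whether a carboxylic acid or a longer alkoxy chain in place of ethoxy on this phenyl would give a number in this assay, and on which side of compound 1 it would fall.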